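Trifluoromethoxy in Place of Trifluoromethyl on the Aromatic Ring

A few compounds are considered here, and "the series" means these few. Any claim that something is new, unique, unknown or untested is made for them only; others in the source may bear on it.

Within the data shown here, compound 2 `COCC(C1CC1)n1nc(C)nc(Nc2c(Cl)cc(C(F)(F)F)cc2Cl)c1=O` gives 11 nM in an assay on isolated protein for displacement of a labelled ligand from corticotropin-releasing factor receptor 1 (Rattus norvegicus) (on this read-out lower numbers stand for stronger inhibition and higher numbers for weaker inhibition), and the only other measured compound, compound 1 `CCC(C1CC1)n1nc(C)nc(Nc2c(Cl)cc(C(F)(F)F)cc2Cl)c1=O`, gives 6.3 nM; the one known step, a 1.7-fold higher number from compound 1 to compound 2 (0.24 log units; within the scatter), leaves the two within the usual scatter of each other. Compound 3 `COCC(C1CC1)n1nc(C)nc(Nc2c(Cl)cc(OC(F)(F)F)cc2Cl)c1=O` differs from compound 2 by trifluoromethoxy in place of trifluoromethyl on an aromatic carbon. Among the measured compounds shown here, the measured step altered a saturated chain, not the aromatic ring, so no measured step bears on this change. Compound 3 is therefore expected to differ little, the step of a 1.4-fold higher number from compound 2 to compound 3 (0.13 log units; within the scatter) lying within the scatter. The estimate for compound 3 is 15 nM, ranging from 5 nM to 45 nM.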

Compound 3, half-maximal inhibitory concentration: 11 nM
Compound 3: the middle estimate sits 1.4-fold (0.13 log units) above what was measured; the range from low to high includes it.
By their numbers in this assay, from the lowest: compounds 1, 2 and 3 (each within the scatter of the next).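

Trifluoromethoxy in place of trifluoromethyl gives no change at the digits printed from compound 2 to compound 3 (within the scatter) in this assay. This aromatic carbon, para to a large group and meta to two chloro groups, therefore accepts one more heavy atom, an oxygen, with no change beyond the scatter. Nothing measured here offers an explanation for this result. Going by these compounds, whether the same carbon accepts a group such as an amine or a carboxylic acid stays open. So does whether this exchange would read the same on compound 1, which carries methyl where compound 2 carries methoxy.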